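Amide cap change on the shared core

The source may report more compounds than this note shows. Statements on the series, on what has been measured and on what is new or still open speak of the compounds shown alone.

Measured so far:
compound 1 `CC(C)N(C(=O)CN1C=CN(c2ccccc2)C(=O)C(Cc2n[nH]c3ccccc23)C1=O)c1ccc(F)cc1` — 282 nM
compound 2 `CCn1nc(CC2(OC)C(=O)N(CC(=O)N(c3ccc(OC)cc3)C(C)C)C=CN(c3ccccc3)C2=O)c2ccccc21` — 31600 nM; > 30000 nM (2 entries)
compound 3 `CC(C)N(C(=O)CN1C=CN(c2ccccc2)C(=O)[C@H](Cc2n[nH]c3cc(F)ccc23)C1=O)c1ccccc1` — 1260 nM

In a functional assay on CHO cells for agonist activity at Melanocortin receptor 4 (Homo sapiens), read by a luciferase reporter, with a stated time of 4 h (on this read-out higher numbers stand for an effect only at larger amounts of compound and lower numbers for an effect already at smaller amounts), compound 1 gives 282 nM, the lowest of the two numbers available. The nearest is compound 3 with 1260 nM, a gap beyond the scatter. Compound 2 is reported only at or beyond the limit of this assay (the several entries of compound 2 in this assay, 31600 nM; > 30000 nM (2 entries)); these entries are limits, not numbers.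

Compound 4 `O=C1C(Cc2n[nH]c3ccccc23)C(=O)N(c2ccccc2)C=CN1CC(=O)N1CCCCc2ccccc21` is not yet measured. It differs from compound 1 in one place: a group of 11 heavy atoms (10 carbon, 1 nitrogen; one six-membered aromatic ring of carbon only, one seven-membered non-aromatic ring with 1 hetero atom) in place of a group of 11 heavy atoms (9 carbon, 1 nitrogen, 1 fluorine; one six-membered aromatic ring of carbon only), on a carbonyl carbon. Among the measured compounds shown here, no pair of measured compounds isolates a change of this kind, so no measured step can guide the size. The expected step from compound 1 to compound 4 is a moderate rise, a 2.5-fold higher number from compound 1 to compound 4 (0.39 log units; beyond the scatter), possibly within the scatter. Compound 4 is estimated at 700 nM, expected between 150 nM and 4000 nM.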

Compound 4, half-maximal effective concentration: 324 nM
Compound 4: the middle estimate sits 2.2-fold (0.33 log units) above what was measured; the measured number falls inside the stated range.
By their numbers in this assay, from the lowest: compounds 1 and 4 (each within the scatter of the next); then compound 3.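

Replacing the group on a carbonyl carbon of the shared core gives a 1.1-fold higher number from compound 1 to compound 4 (0.06 log units; within the scatter). In this assay, a group with one seven-membered non-aromatic ring with 1 hetero atom can therefore stand at this place without a difference beyond the scatter, so this position accepts more than the group of compound 1. Nothing measured here accounts for this result.

Still open, from the compounds shown here alone, is how a group carrying an amine or a carboxylic acid at this place would read out. Going by these compounds, the effect of a smaller ring in the entering group also remains unknown.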